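A few compounds are considered here, and "the series" means these few. Any claim that something is new, unique, unknown or untested is made for them only; others in the source may bear on it.

Compound 1 `OCC(O)Cn1nc2c(Br)c(Br)c(Br)c(Br)c2n1`: 116%
Compound 2 `OC(CCn1nc2c(Br)c(Br)c(Br)c(Br)c2n1)c1ccc(Br)cc1`: 107%

In a functional assay on MCF7 cells (Homo sapiens) for antiproliferative activity, read by MTT assay, with a stated time of 48 h, tested at 12.5 uM (a lower number here means a stronger effect, a higher number a weaker effect of the compound at the concentration tested), compound 2 gives 107%, the smaller of the two numbers shown, while compound 1 sits within the usual scatter of it. Compound 3 `OC(CCn1nc2c(Br)c(Br)c(Br)c(Br)c2n1)c1ccccc1` differs from compound 2 by hydrogen in place of bromo on an aromatic carbon. Within the data shown here, no measured pair tracks this change, so the step is expected to stay within the scatter: a number 1 percentage points higher from compound 2 to compound 3 (within the scatter) is the estimated shift. On that basis compound 3 is expected to give 108%, with a range from 95% to 120%.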

Compound 3, a percentage reported as activity, at one concentration (the size of the read-out at that concentration, not a potency): 113%
The estimate for compound 3 lay 5 percentage points below the measured number, within the range that was stated.
By their numbers in this assay, from the lowest: compounds 2, 3 and 1 (each within the scatter of the next).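

The change from 4-bromophenyl to phenyl gives a number 6 percentage points higher from compound 2 to compound 3 (within the scatter) in this assay. Among these compounds, this pair is the first to isolate this position on the aromatic ring, and at the concentration tested, exchanging the bromo for hydrogen there leaves the read-out within the usual scatter. No measured evidence bears on this result.

On these data alone, whether an amine or a carboxylic acid at this place on the phenyl ring would bring the number down stays open. So does the effect of a longer chain on the shared core.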